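Chloro in Place of Nitro: Expected Cytotoxicity of Compound 3

The source may report more compounds than this note shows. Statements on the series, on what has been measured and on what is new or still open speak of the compounds shown alone.

Measured so far:
Compound 1, `Cc1c(/N=C/c2ccc(N(C)C)cc2)c(=O)n(-c2ccccc2)n1C`: 468000000 nM
Compound 2, `Cc1c(/N=C/c2cccc([N+](=O)[O-])c2)c(=O)n(-c2ccccc2)n1C`: 490000000 nM

Of the compounds shown here, two sharing one core have been tested in a functional assay on P388 cells (Mus musculus) for cytotoxicity, read by MTT assay, with a stated time of 72 h; a higher number here means a weaker inhibitor, a lower number a stronger inhibitor. Compound 1 gives 468000000 nM, and compound 2 gives 490000000 nM. The two numbers sit within the usual scatter of each other, so neither compound can be called the stronger or the weaker inhibitor on these data. Both numbers are very high, which marks weak cytotoxicity for the pair.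

Compound 3 `Cc1c(/N=C/c2cccc(Cl)c2)c(=O)n(-c2ccccc2)n1C` has not yet been measured. It differs from compound 2 in one place: chloro in place of nitro on an aromatic carbon. Going by the values given here, no pair of measured compounds shows the size of such a step, so the expectation rests only on the two values shown. Since compound 1 and compound 2 land so close together despite carrying different groups on the same ring, the number for compound 3 is expected to stay near that of compound 2. The step from compound 2 to compound 3 is expected to be a 1.0-fold lower number from compound 2 to compound 3 (0.02 log units; within the scatter), none beyond the scatter. Compound 3 is therefore estimated at 470000000 nM in this assay, with a range from 200000000 nM to 1000000000 nM.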

Compound 3, half-maximal inhibitory concentration: 550000000 nM
For compound 3 the middle estimate is 1.2-fold (0.07 log units) below the measured one; the measured number falls inside the stated range.
By their numbers in this assay, from the lowest: compounds 1, 2 and 3 (each within the scatter of the next).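

In this assay, going by these compounds alone, compounds 2 and 3 form the first pair that differs in only one place, and chloro in place of nitro on an aromatic carbon, meta to a large group, gives a 1.1-fold higher number from compound 2 to compound 3 (0.05 log units; within the scatter). This step shows that exchanging nitro, with 3 heavy atoms and 2 hydrogen-bond acceptors, for chloro, with 1 heavy atom and 0 hydrogen-bond acceptors, does not separate the two compounds at this position, and compound 3, at 550000000 nM, remains very weakly cytotoxic. No measurement shown explains why this exchange leaves the two numbers within the scatter of each other.

The compounds shown leave open whether any group at this position can move the number beyond the scatter, since a single exchange cannot settle this, and an amine, a hydroxyl or a carboxylic acid could each test it in this assay. They also leave open whether a change elsewhere on the shared core, such as a longer chain in place of one of its methyl groups, would give a clearly lower number.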